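Terminal ring swap on the CXCR4 antagonist series

The source may hold more compounds than are shown below. What is called first, only, known or untested is meant among the compounds shown, and "the series" means these compounds.

Of the compounds shown here, three sharing one core have been measured in a functional assay on cells for antagonist activity at C-X-C chemokine receptor type 4 (Homo sapiens), read by fluorescence and calcium flux, with stated times of 25 min and 90 s; a higher number here means a weaker inhibitor, a lower number a stronger inhibitor. Compound 1 `c1ccc(CNCCCCN(C[C@H]2Cc3ccccc3CN2)[C@H]2CCCc3cccnc32)cc1` gives 20.1 nM, compound 2 `c1ccc2c(c1)CN[C@@H](CN(CCCCNCC1CCCCC1)[C@H]1CCCc3cccnc31)C2` gives 158 nM, and compound 3 `CC1(C)CCC(NCCCCN(C[C@H]2Cc3ccccc3CN2)[C@H]2CCCc3cccnc32)CC1` gives 77.6 nM. Compound 3 stands second highest of the three numbers: the step of a 3.9-fold higher number from compound 1 to compound 3 (0.59 log units; beyond the scatter) was a modest rise, and the step of a 2.0-fold lower number from compound 2 to compound 3 (0.31 log units; beyond the scatter) was a modest fall, so compound 3 sits nearer to compound 2 than to compound 1.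

Compound 4 `CC(C)(CCN(C[C@H]1Cc2ccccc2CN1)[C@H]1CCCc2cccnc21)CNC1CCOCC1` has not yet been measured. Its difference from compound 3 is a group of 11 heavy atoms (9 carbon, 1 nitrogen, 1 oxygen; one six-membered non-aromatic ring with 1 hetero atom) in place of a group of 11 heavy atoms (10 carbon, 1 nitrogen; one six-membered non-aromatic ring of carbon only), on a saturated chain carbon, two bonds along the chain from an amine nitrogen. Going by the values given here, no measured step changes this part of the molecule in the same way; the nearest comparisons, a 3.9-fold higher number from compound 1 to compound 3 (0.59 log units; beyond the scatter) and a 2.0-fold lower number from compound 2 to compound 3 (0.31 log units; beyond the scatter), alter the group on the terminal amine nitrogen and both stayed modest, while a 7.9-fold higher number from compound 1 to compound 2 (0.90 log units; beyond the scatter) was the largest change seen, also modest. On that basis the step of a 1.5-fold higher number from compound 3 to compound 4 (0.19 log units; within the scatter) is expected to be modest and is estimated to go toward a somewhat higher number. For compound 4 the value in this assay is estimated at 120 nM, with a range from 35 nM to 400 nM.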

Compound 4, half-maximal inhibitory concentration: 36.3 nM
Estimate against measurement, compound 4: 3.3-fold (0.52 log units) above; the measured number falls inside the stated range.
By their numbers in this assay, from the lowest: compounds 1 and 4 (each within the scatter of the next); then compound 3; then compound 2.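

Compound 4 shows that, at this place on a saturated chain carbon, a six-membered non-aromatic ring need not carry the cost seen with the rings of carbon only: the ring with 1 hetero atom gives a modest fall against both of those compounds, in steps beyond the scatter (in this assay, a 2.1-fold lower number from compound 3 to compound 4 (0.33 log units; beyond the scatter), and a 4.4-fold lower number from compound 2 to compound 4 (0.64 log units; beyond the scatter)). Against the aromatic ring of compound 1, the same kind of swap stays within the scatter (a 1.8-fold higher number from compound 1 to compound 4 (0.26 log units; within the scatter)), so among these four compounds an aromatic ring of carbon only is not needed to reach that level, and compound 4 is the only compound with a non-aromatic ring for which this holds. No supporting measurement is available to say why the ring with 1 hetero atom behaves differently from the rings of carbon only.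

This reading rests on a single ring with an oxygen as its hetero atom, so the compounds shown leave open whether the result is tied to that atom. A piperidine, with nitrogen in the ring, or a five-membered tetrahydrofuran at the same place would test how far it extends.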